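A few compounds are considered here, and "the series" means these few. Any claim that something is new, unique, unknown or untested is made for them only; others in the source may bear on it.

Three compounds of one shared core have been examined in a functional assay, with a stated time of 20 min; a higher number here means a weaker inhibitor, a lower number a stronger inhibitor. Compound 1, `COc1ccc(-c2nc(SC)n(C)c(=O)c2C#N)cc1`, gives 58 ug/mL in this assay. Compound 2, `COc1ccc(-c2nc(NN)n(C)c(=O)c2C#N)cc1`, gives 41 ug/mL. These two differ in one place only, (aminoamino in place of methylsulfanyl on an aromatic carbon), and the step is a 1.4-fold lower number from compound 1 to compound 2 (0.15 log units; within the scatter). Compound 3, `CSc1nc(-c2cccs2)c(C#N)c(=O)n1C`, gives 71 ug/mL; of the three numbers it is the highest, yet its gap to compound 1 and its gap to compound 2 both sit within the scatter, so no order among the three can be read from these values. How the core of compound 3 differs from the core of compound 1 is not broken down here.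

Compound 4, `Cn1c(NN)nc(-c2cccs2)c(C#N)c1=O`, has not yet been measured in this assay. It is made from compound 3 by the same kind of change that leads from compound 1 to compound 2: aminoamino in place of methylsulfanyl on an aromatic carbon. The surroundings of the place differ in one respect: in compound 3 the changed carbon is meta to a thiophen-2-yl group, whereas in compound 1 it is meta to a group of 8 heavy atoms.

Because the earlier step of the same kind was a 1.4-fold lower number from compound 1 to compound 2 (0.15 log units; within the scatter), a step of about a 1.4-fold lower number from compound 3 to compound 4 (0.15 log units; within the scatter) is expected from compound 3 to compound 4, resting on that single precedent alone. For compound 4 the value expected in this assay is 50 ug/mL, with a likely range from 30 ug/mL to 85 ug/mL.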

Compound 4, half-maximal inhibitory concentration: 61 ug/mL
Estimate against measurement, compound 4: 1.2-fold (0.09 log units) below; low and high end bracket the measured number.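

Replacing methylsulfanyl with aminoamino on the core of compound 3 gives, in this assay, a 1.2-fold lower number from compound 3 to compound 4 (0.07 log units; within the scatter), so on this core too the change leaves the two values within the scatter of each other. Set beside the earlier case, the change reads alike on the two cores, one carrying a thiophen-2-yl group and the other a group of 8 heavy atoms: the same change on two cores in this assay, a 1.4-fold lower number (0.15 log units; within the scatter) from compound 1 to compound 2 and a 1.2-fold lower number (0.07 log units; within the scatter) from compound 3 to compound 4, 1.2-fold (0.08 log units) apart, within the scatter of two such steps. This shows that the change can be carried between these two cores without a step beyond the scatter on either; it does not show that the change strengthens or weakens inhibition on either core, and two such small steps say nothing about how it would read on any further core.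

The compounds shown leave open whether another group on the same aromatic carbon, such as a simple amine, a morpholine ring or a longer alkyl chain, would give a step beyond the scatter. They also leave open how the aminoamino change would read with a carboxylic acid in place of the cyano group.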